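Swapping a Branched Chain for a Ring-Bearing Chain

The compounds below may be only part of what the source reports. "The series", "measured", "known", "first", "only" and "open" are said of these compounds alone.

Within the data shown here, compound 2 `CCCC(C)Oc1cccc2ccc(N)nc12` gives 105 nM in an assay on cells with melanin-concentrating hormone receptor 1 (Homo sapiens) as the target, read by radioligand binding (on this read-out lower numbers stand for stronger inhibition and higher numbers for weaker inhibition), the higher of the two numbers measured so far. Compound 1 `CCC(C)COc1cccc2ccc(N)nc12` gives 36 nM, and the shift between them was a 2.9-fold higher number from compound 1 to compound 2 (0.46 log units; beyond the scatter). Compound 3 `Nc1ccc2cccc(OCC3CCOC3)c2n1` differs from compound 2 by (oxolan-3-yl)methyl in place of 1-methylbutyl on an oxygen on an aromatic ring. Among the measured compounds shown here, only that single measured step bears on this change, and it shows that reshaping the chain on the oxygen moves this assay by a modest amount. A drop of similar size is therefore expected, a 2.1-fold lower number from compound 2 to compound 3 (0.32 log units; beyond the scatter). Compound 3 is estimated at 50 nM, with a likely range from 15 nM to 180 nM.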

Compound 3, half-maximal inhibitory concentration: 115 nM
For compound 3 the middle estimate is 2.3-fold (0.36 log units) below the measured one, and the stated range covers the measured number.
By their numbers in this assay, from the lowest: compound 1; then compounds 2 and 3 (each within the scatter of the next).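

In this assay, the ring-bearing (oxolan-3-yl)methyl in place of the open-chain 1-methylbutyl gives a 1.1-fold higher number from compound 2 to compound 3 (0.04 log units; within the scatter), so at this oxygen a ring with a hydrogen-bond acceptor can stand in for that chain with no readable shift. Compared with the 2-methylbutyl chain, the same group gives a 3.2-fold higher number from compound 1 to compound 3 (0.50 log units; beyond the scatter), which leaves compound 1 with the lowest number of the three. No supporting data explain these differences. Still open, on these data alone, is how an amine or a longer chain on this oxygen would compare, and whether a ring of another size would match compound 1.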